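Replacing the piperidinylmethyl arm: microsomal clearance notes

The source may hold more compounds than are shown below. What is called first, only, known or untested is meant among the compounds shown, and "the series" means these compounds.

Measured so far in an ADME assay on microsomes from liver (Mus musculus, strain CD1) for metabolic stability, read by HPLC, using NADPH, with a stated time of 30 min; on this read-out higher numbers stand for fast clearance and lower numbers for slow clearance:
- compound 1 `COc1cccc(NC(=O)c2nnn(CC3CCNCC3)c2N)c1`: < 0.5 mL.min-1.g-1
- compound 2 `COc1cccc(NC(=O)c2nnn(Cc3ccc(-n4cccn4)cc3)c2N)c1`: 2.3 mL.min-1.g-1
- compound 3 `COc1cccc(NC(=O)c2nnn(Cc3ccccc3)c2N)c1`: 3.7 mL.min-1.g-1

Compound 1 returns no number in this assay, only a limit: it sits at the limit of < 0.5 mL.min-1.g-1 in this assay, at which 1 of the 3 values shown sits. On the numbers available it is therefore the slowest-cleared of the three, with its exact value unknown.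

Compound 4 `COc1cccc(NC(=O)c2nnn(Cc3ccc(C(C)C)cc3)c2N)c1` has not been measured. It differs from compound 1 by 4-isopropylphenyl in place of piperidin-4-yl on a saturated chain carbon bound to an aromatic nitrogen.

For the measured compounds named here, the one step that bears directly on this change is an at least 7.4-fold higher number from compound 1 to compound 3 (0.86 log units; beyond the scatter), which shares the exchange of the saturated ring for a benzyl-type group at the same position and is beyond the scatter. The step of a 1.6-fold higher number from compound 2 to compound 3 (0.21 log units; within the scatter) shows that a substituent on the benzene ring did not move the number beyond the scatter. A rise beyond the scatter is therefore expected for compound 4, in the direction of faster clearance, as in an at least 10-fold higher number from compound 1 to compound 4 (1.00 log units; beyond the scatter).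

Compound 4 is estimated at 5 mL.min-1.g-1, with a likely range from 2 mL.min-1.g-1 to 12 mL.min-1.g-1.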

Compound 4, intrinsic clearance in microsomes: 3.2 mL.min-1.g-1
The estimate for compound 4 lay 1.6-fold (0.19 log units) above the measured number; low and high end bracket the measured number.
By their numbers in this assay, from the lowest: compounds 2, 4 and 3 (each within the scatter of the next). At a limit, below all of these: compound 1.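

In this assay the step of an at least 6.4-fold higher number from compound 1 to compound 4 (0.80 log units; beyond the scatter) shows that the rise seen with phenyl in compound 3 also holds for a second aromatic arm, 4-isopropylphenyl in place of piperidin-4-yl. Isopropyl on the benzene ring moves nothing beyond the scatter, with a 1.2-fold lower number from compound 3 to compound 4 (0.06 log units; within the scatter) and a 1.4-fold higher number from compound 2 to compound 4 (0.14 log units; within the scatter), so hydrogen, 1H-pyrazol-1-yl and isopropyl at this place cannot be told apart in this assay. Compound 1 remains a limit of the assay and not a number, which leaves the full size of its steps unknown: the limit of < 0.5 mL.min-1.g-1 in this assay, at which 1 of the 4 values shown sits.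

Still open, on these data alone, is whether the low number of compound 1 follows the ring nitrogen or the saturated ring: a cyclohexyl arm, or a phenyl arm carrying an aminomethyl group, would separate the two. Also open, as far as these compounds go, is whether another group on the benzene ring, such as a carboxylic acid, moves the number beyond the scatter.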